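Compound 3 Trades Tert-Butyl for Methyl

The source may report more compounds than this note shows. Statements on the series, on what has been measured and on what is new or still open speak of the compounds shown alone.

In a functional assay on MRC5 cells (Homo sapiens) for cytotoxicity, read by colorimetric assay and MTT assay (on this read-out lower numbers stand for higher toxicity in this test and higher numbers for lower toxicity in this test), compound 3 `CC(C)(C)c1ccc(O)c(/C=N/NC(=O)c2ccc(Cl)cc2)c1` gives 3600 nM, the lowest number among those measured so far. Compound 1 `COc1ccc(C(=O)N/N=C/c2cc(C(C)(C)C)ccc2O)cc1` gives only a limit of the test, > 100000 nM. Compound 4 `Cc1ccc(O)c(/C=N/NC(=O)c2ccc(Cl)cc2)c1` has methyl in place of tert-butyl on an aromatic carbon of compound 3, para to a hydroxy group (methyl in place of tert-butyl on an aromatic carbon). Within the data shown here, the one measured step, an at least 27-fold lower number from compound 1 to compound 3 (1.44 log units; beyond the scatter), is large, but it is chloro in place of methoxy, and compound 4 keeps that chloro, so it does not bear directly on this change. Compound 2 `Cc1ccc(O)c(/C=N/NC(=O)c2ccc(C(C)(C)C)cc2)c1` also carries the methyl and gives 16300 nM, so a modest move to a higher number is expected. The expected step is a 2.5-fold higher number from compound 3 to compound 4 (0.40 log units; beyond the scatter). Compound 4 is estimated at 9000 nM, within a range of 3000 nM to 30000 nM.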

Compound 4, half-maximal cytotoxic concentration: > 100000 nM
Compound 4 was reported as a limit; the forecaster's own chance of this, stated with the estimate: 8%; middle value at least 11-fold (1.04 log units) away from the limit.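

Methyl in place of tert-butyl on an aromatic carbon, para to a hydroxy group, gives an at least 27-fold higher number from compound 3 to compound 4 (1.44 log units; beyond the scatter), so with chloro held constant, the measurable number in this assay depends on that tert-butyl. The other new step is an at least 6.1-fold higher number from compound 2 to compound 4 (0.78 log units; beyond the scatter), so removing the remaining tert-butyl also matters, although compound 1 carries one and still reaches a limit. Compound 4 sits at a limit of the test, so neither step has a fixed size: the limit of > 100000 nM in this assay, at which 2 of the 4 values shown sit.

From the compounds shown here alone, whether an ethyl or isopropyl group at that carbon would restore a measurable number stays open. So does the true size of either step.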